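The source may hold more compounds than are shown below. What is called first, only, known or untested is meant among the compounds shown, and "the series" means these compounds.

Working notes on the series. In a functional assay on A549 cells (Homo sapiens) for cytotoxicity, read by MTT assay, with a stated time of 48 h (on this read-out higher numbers stand for weaker inhibition and lower numbers for stronger inhibition), compound 1 `COc1ccc(C2=NOC(COc3ccc(-c4nnnn4-c4cc(OC)c(OC)c(OC)c4)cc3N)C2)cc1N` gives 2080 nM and compound 2 `COc1cc(-n2nnnc2-c2ccc(OCC3CC(c4ccc(OC)c(OC)c4OC)=NO3)c(N)c2)cc(OC)c1OC` gives 2030 nM. Among the measured compounds shown here, compound 2 therefore stands level with compound 1, its only measured neighbour, and the two cannot be separated on these numbers.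

Compound 3 `COc1cc(-n2nnnc2-c2ccc(OCC3CC(c4ccccc4F)=NO3)c(N)c2)cc(OC)c1OC` changes the same place on the shared core: 2-fluorophenyl in place of 2,3,4-trimethoxyphenyl on a carbon with a double bond to nitrogen. For the measured compounds named here, only one measured step bears on this place, a 1.0-fold lower number from compound 1 to compound 2 (0.01 log units; within the scatter). That step exchanged 3-amino-4-methoxyphenyl for 2,3,4-trimethoxyphenyl and left the number within the scatter. Going by the values given here, no measured compound yet carries 2-fluorophenyl, so a single step gives only weak guidance.

In this assay no clear shift in either direction is expected because of a 1.0-fold lower number from compound 1 to compound 2 (0.01 log units; within the scatter). The expected step is a 1.2-fold higher number from compound 2 to compound 3 (0.07 log units; within the scatter). For compound 3 the estimate is 2400 nM, with an expected range of 900 nM to 6000 nM.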

Compound 3, half-maximal inhibitory concentration: 1490 nM
For compound 3 the middle estimate is 1.6-fold (0.21 log units) above the measured one; measured number inside the range.
By their numbers in this assay, from the lowest: compounds 3, 2 and 1 (each within the scatter of the next).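

The change from 12 heavy atoms and 3 hydrogen-bond acceptors in 2,3,4-trimethoxyphenyl to 7 heavy atoms and 0 hydrogen-bond acceptors in 2-fluorophenyl gives a 1.4-fold lower number from compound 2 to compound 3 (0.13 log units; within the scatter) in this assay on the carbon with a double bond to nitrogen. Putting 2-fluorophenyl in place of 3-amino-4-methoxyphenyl gives a 1.4-fold lower number from compound 1 to compound 3 (0.14 log units; within the scatter) and so this position now holds three different substituted phenyl groups that cannot be separated in this assay on these numbers. Nothing available explains why these numbers stay so close.

On these data alone, all three compounds carry a phenyl ring at this place, so it remains open whether a group without that ring, such as a short alkyl chain or a morpholine, would give a step beyond the scatter. A carboxylic acid on the phenyl ring also remains untested in the compounds shown here.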